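The source may hold more compounds than are shown below. What is called first, only, known or untested is meant among the compounds shown, and "the series" means these compounds.

Measured in a functional assay (Nicotiana tabacum); a higher number here means a weaker inhibitor, a lower number a stronger inhibitor:
- compound 1 `CCCCCCNc1nc(SC)nc2ncccc12`: 3330 nM
- compound 2 `CSc1nc(NC2CC2)c2cccnc2n1`: 4900 nM
- compound 3 `CSc1nc(Nc2ccccc2)c2cccnc2n1`: 15900 nM

Compound 3 has the highest number of the three, which makes it the weakest inhibitor here. Compound 4 `CCOc1ccc(Nc2nc(SC)nc3ncccc23)cc1` has ethoxy in place of hydrogen on an aromatic carbon of the phenyl group of compound 3, para to a large group (ethoxy in place of hydrogen on an aromatic carbon). Going by the values given here, no measured step changes anything on that phenyl ring, so the evidence is indirect. The nearest steps replace the whole group on the same nitrogen. There is a 1.5-fold higher number from compound 1 to compound 2 (0.17 log units; within the scatter), and the two modest steps are a 3.2-fold higher number from compound 2 to compound 3 (0.51 log units; beyond the scatter) and a 4.8-fold higher number from compound 1 to compound 3 (0.68 log units; beyond the scatter). These show a moderate range in this assay for changes at this nitrogen, and the added ethoxy is a smaller change than any of them. A step beyond the scatter is therefore not expected, with only a slight lean towards a lower number. The expected change is a 1.4-fold lower number from compound 3 to compound 4 (0.16 log units; within the scatter). Compound 4 is estimated at 11000 nM, with an expected range of 3500 nM to 32000 nM.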

Compound 4, half-maximal inhibitory concentration: 5420 nM
Compound 4: the middle estimate sits 2.0-fold (0.31 log units) above what was measured; the measured number falls inside the stated range.
By their numbers in this assay, from the lowest: compounds 1, 2 and 4 (each within the scatter of the next); then compound 3.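

In this assay, ethoxy in place of hydrogen on an aromatic carbon, para to a large group, gives a 2.9-fold lower number from compound 3 to compound 4 (0.47 log units; beyond the scatter) and is the only step shown that changes the phenyl ring itself. Changes at this part of the molecule are therefore not limited to replacing the whole group on the nitrogen: a substituent on the ring can also move the number beyond the scatter, here towards a stronger inhibitor. Nothing measured on these compounds explains the step.

The compounds shown leave open whether this gain belongs to ethoxy in particular or would also appear with methoxy, hydroxyl, fluorine or a longer alkoxy chain on the same carbon. They also leave open whether an amine or a carboxylic acid there would shift the number in the same direction.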